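This account rests on a few compounds, and the source may have more. Where it says the series, first, only, none or still open, it means among the compounds named here.

Measured so far in an ADME assay on microsomes from liver (Homo sapiens) for metabolic stability, read by LC-MS, with NADPH named in the record, with a stated time of 60 min, tested at 1 uM, in the absence of a further agent (on this read-out lower numbers stand for a less stable compound and higher numbers for a more stable compound), are two compounds
- compound 1 `CC(=O)N[C@@H]1CCN(c2cc(C)nn3c(-c4ccccc4)c(C)nc23)C1` gives > 95% (a limit)
- compound 2 `CCCCCC(=O)N[C@@H]1CCN(c2cc(C)nn3c(-c4ccc(OC)c(OC)c4)c(C)nc23)C1` gives > 95% (a limit)

Compound 2 stands at > 95% as a limit of the assay, not as a number. Among the measured compounds shown here, the pair offers only the limit of > 95% in this assay, at which 2 of the 2 values shown sit, as evidence, and no measured step is available to size a change.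

Next is compound 3 `COc1ccc(-c2c(C)nc3c(N4CC[C@@H](NC(=O)OCc5ccccc5)C4)cc(C)nn23)cc1OC`, which departs from compound 2 in one place, with benzyloxy in place of pentyl on a carbonyl carbon as the change: benzyloxy in place of pentyl on a carbonyl carbon. The same difference reads pentylcarbonyl to benzyloxycarbonyl.

For the measured compounds named here, with no measured step as a guide, a small fall in this assay is expected, and no change beyond the scatter remains quite possible. The step of a number at least 7 percentage points lower from compound 2 to compound 3 (that floor lies within the scatter) is the expected size of that fall. Compound 3 is estimated at 88% with an expected range from 65% to 100% for a repeat measurement.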

Compound 3, percent of the compound remaining: > 95%
Compound 3 ended at the assay's limit; the forecaster's own chance of this, stated with the estimate: 40%; middle value at least 7 percentage points away from the limit.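

The step from compound 2 to compound 3 cannot be read in this assay: both values are limits of the assay, not numbers. The compounds shown leave open whether benzyloxy in place of pentyl on a carbonyl carbon changes the percent remaining at all, and which change would bring a value off the limit.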